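The source may hold more compounds than are shown below. What is called first, only, known or untested is meant among the compounds shown, and "the series" means these compounds.

Values in a functional assay on HeLa S3 cells (Homo sapiens) for antiproliferative activity, read by XTT assay, with a stated time of 72 h; a higher number here means a weaker inhibitor, a lower number a stronger inhibitor:
Compound 1 `COc1ncnc2c1c(-c1ccccc1)cn2[C@@H]1O[C@H](CO)[C@@H](O)[C@H]1O`: > 20000 nM
Compound 2 `COc1ncnc2c1c(-c1cc3ccccc3o1)cn2[C@@H]1O[C@H](CO)[C@@H](O)[C@H]1O`: 9240 nM

The entry for compound 1 is a limit of the assay and not a number. Among the compounds with values here, compound 2 holds the only actual number, 9240 nM. Compound 3 `C#Cc1cn([C@@H]2O[C@H](CO)[C@@H](O)[C@H]2O)c2ncnc(OC)c12` replaces the 1-benzofuran-2-yl of compound 2 with ethynyl on the same aromatic carbon: ethynyl in place of 1-benzofuran-2-yl on an aromatic carbon. Within the data shown here, the only measured step at this place, an at least 2.1-fold lower number from compound 1 to compound 2 (0.33 log units; beyond the scatter), is modest and rests on a limit, and it does not involve ethynyl. No clear change is therefore expected in this assay, and the estimated 1.5-fold lower number from compound 2 to compound 3 (0.19 log units; within the scatter) stays within the scatter, with either direction open. For compound 3 the estimate is 6000 nM, with an expected range of 800 nM to 20000 nM.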

Compound 3, half-maximal inhibitory concentration: 1730 nM
Beside the measured number, compound 3's estimate is 3.5-fold (0.54 log units) above it; the measured number falls inside the stated range.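

In this assay, the aromatic carbon two ring bonds from the ring nitrogen responds to a group with no ring at all: ethynyl gives a 5.3-fold lower number from compound 2 to compound 3 (0.73 log units; beyond the scatter), and compound 3 stands as the strongest of the three. The step from phenyl, an at least 11-fold lower number from compound 1 to compound 3 (1.06 log units; beyond the scatter), is larger still, so aromatic rings at this place are not needed for activity. Compound 1 carries a limit of the assay and not a number: the limit of > 20000 nM in this assay, at which 1 of the 3 values shown sits.

Whether the triple bond itself or the absence of a ring accounts for the drop stays open. A nitrile, an ethyl group or a longer alkyne chain on this carbon would bear on that question.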